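A few compounds are considered here, and "the series" means these few. Any claim that something is new, unique, unknown or untested is made for them only; others in the source may bear on it.

Measured compounds:
compound 1 `CC(C)Cn1c(=O)n(C)c(=O)c2nc([S+]([O-])CCCO)c(Cc3cccc4ccccc34)nc21` — "not determined" (no result reported)
compound 2 `CC(C)Cn1c(=O)n(C)c(=O)c2nc(CCCCO)c(Cc3cccc4ccccc34)nc21` — > 2000 nM

In an assay on MCF7 cells for inhibition of Monocarboxylate transporter 1 (Homo sapiens), read by scintillation counting, with a stated time of 10 min (a higher number here means a weaker inhibitor, a lower number a stronger inhibitor), compound 1 gives "not determined" (no result reported). Compound 2 gives > 2000 nM, a limit rather than a number. It therefore stands at the limit of > 2000 nM in this assay, at which 1 of the 2 values shown sits, so no measured value in this assay is available as a reference point for the series. Compound 3 `CC(C)Cn1c(=O)n(C)c(=O)c2nc(/C=C\CCCO)c(Cc3cccc4ccccc34)nc21` differs from compound 2 by 5-hydroxypent-1-en-1-yl in place of 4-hydroxybutyl on an aromatic carbon. Among the measured compounds shown here, no step between measured compounds exists here, so nothing sets the size of this change; no shift beyond the usual scatter is expected, and a further limit is the most likely outcome. Compound 3 is estimated at 3000 nM, with a range from 800 nM to 15000 nM. The expected step that the limit leaves unreadable from compound 2 to compound 3 is taken to lie within the scatter.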

Compound 3, half-maximal inhibitory concentration: 116 nM
The estimate for compound 3 lay 26-fold (1.41 log units) above the measured number; the whole stated range lies above it.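

In this assay, 5-hydroxypent-1-en-1-yl in place of 4-hydroxybutyl on this aromatic carbon gives an at least 17-fold lower number from compound 2 to compound 3 (1.23 log units; beyond the scatter). The chain at this position therefore has a large bearing on the read-out, which compound 1 and compound 2 alone could not show. Compound 2 holds a limit and not a number: the limit of > 2000 nM in this assay, at which 1 of the 3 values shown sits.

The change adds both a double bond and a heavy atom, and the compounds shown do not separate the two. Also open, going by these compounds, is how an amine or a carboxylic acid in place of the terminal hydroxyl would read.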